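Terminal alkyne replacing alkene in the side-chain series

The source may hold more compounds than are shown below. What is called first, only, known or untested is meant among the compounds shown, and "the series" means these compounds.

Series notes on the chain variants of the shared core. Compound 1 `CCCCCCc1cc2cn([C@H]3C[C@H](O)[C@@H](CO)O3)c(=O)nc2o1` carries the shortest chain. In a functional assay on HEL cells (Homo sapiens) for cytotoxicity, read by microscopy (on this read-out lower numbers stand for higher toxicity in this test and higher numbers for lower toxicity in this test), compound 1 gives only a limit, > 50000 nM. Compound 2 `CCCCCCCCCCc1cc2cn([C@H]3C[C@H](O)[C@@H](CO)O3)c(=O)nc2o1` extends that chain; in this assay compound 2 also reaches only a limit, > 50000 nM. Compound 3 `C=CCCCCCCCCc1cc2cn([C@H]3C[C@H](O)[C@@H](CO)O3)c(=O)nc2o1` is the third chain variant, and in this assay compound 3 likewise gives only a limit, > 50000 nM. Going by the values given here, compound 3 thus stands where both others stand, at the limit of > 50000 nM in this assay, at which 3 of the 3 values shown sit, and none of the measured steps can be sized: a step that the two limits leave unreadable from compound 1 to compound 2, a step that the two limits leave unreadable from compound 1 to compound 3 and a step that the two limits leave unreadable from compound 2 to compound 3 all fall between two limits.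

Compound 4 `C#CCCCCCCc1cc2cn([C@H]3C[C@H](O)[C@@H](CO)O3)c(=O)nc2o1` is the next variant, not yet measured. Its change from compound 3 is ethynyl in place of but-3-en-1-yl on a saturated chain carbon, six bonds along the chain from an aromatic carbon. Among the compounds with values here, no measured step offers a readable size for this change, so no direction can be drawn from the series; the only reference is that every chain variant so far sits at the limit of > 50000 nM in this assay, at which 3 of the 3 values shown sit. Compound 4 is therefore expected to remain at the limit as well, the expected step being a step that the limit leaves unreadable from compound 3 to compound 4, nothing beyond the scatter. The estimate for compound 4 in this assay is 80000 nM, within 25000 nM to 300000 nM.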

Compound 4, minimum cytotoxic concentration: > 200000 nM
Compound 4: no number, only a limit; the forecaster's own chance of this, stated with the estimate: 85%; at least 2.5-fold (0.39 log units) between middle value and limit.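

In this assay compound 4 gives only a limit, > 200000 nM. Compound 1, compound 2 and compound 3 also stand only at limits, so none of their steps to compound 4 can be read. The compounds shown leave open whether any of these chain variants has a measurable value in this assay, and thus what size the change to ethynyl has.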